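The compounds below may be only part of what the source reports. "The series", "measured", "known", "first", "only" and "open" are said of these compounds alone.

In a functional assay on A549 cells (Homo sapiens) for cytotoxicity, read by MTT assay, with a stated time of 72 h (on this read-out higher numbers stand for weaker inhibition and lower numbers for stronger inhibition), compound 1 `CCC[S+]([O-])CCCCN=C=S` gives 10700 nM. Compound 2 `CC(C)[S+]([O-])CCCCN=C=S` gives 10400 nM, level with it, while compound 3 `COc1ccc(C[S+]([O-])CCCCN=C=S)cc1` gives 32600 nM, a higher number than compound 1 shows. Compound 1 therefore shares the lower end of this small set with compound 2.

The next compound, compound 4 `[O-][S+](CCCCN=C=S)Cc1cccs1`, changes the same part of the structure as these neighbours, with thiophen-2-yl in place of ethyl on a saturated chain carbon bound to a sulfur.

Within the data shown here, only one direct step is available, a 1.0-fold lower number from compound 1 to compound 2 (0.01 log units; within the scatter), with isopropyl in place of propyl on a sulfur. That swap brings in no ring, so it says little about the new group. Among the measured compounds shown here, compound 3, at 32600 nM, is the only measured compound that, like compound 4, carries an aromatic ring, and it is the closer guide. It is a single example with a different ring, so only part of its gap from compound 1 is expected to carry over. In this assay, a small move towards a higher number is therefore expected, one that may not clear the usual scatter.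

The estimated step is a 1.5-fold higher number from compound 1 to compound 4 (0.17 log units; within the scatter).

Compound 4 is estimated to give 16000 nM, with an expected range of 7000 nM to 36000 nM.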

Compound 4, half-maximal inhibitory concentration: 8410 nM
Compound 4: middle estimate off by 1.9-fold (0.28 log units), on the high side; low and high end bracket the measured number.
By their numbers in this assay, from the lowest: compounds 4, 2 and 1 (each within the scatter of the next); then compound 3.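

In this assay, putting thiophen-2-yl in place of ethyl on a saturated chain carbon bound to a sulfur gives a 1.3-fold lower number from compound 1 to compound 4 (0.10 log units; within the scatter), so this swap leaves the number level even though it adds an aromatic ring with a sulfur atom in it. Among these compounds, this is the first sign that a ring at this position does not by itself bring a higher number: compound 3, which also carries an aromatic ring, stands at 32600 nM, while compound 4 stays with the two ring-free compounds, and the position tolerates a larger group here without a clear change in this cell assay. Nothing measured explains why the two ring-bearing compounds part ways, and no separate data bear on this result.

As far as these compounds go, it remains open whether the higher number of compound 3 comes from its methoxy group or from the ring that carries it, and a plain benzyl group at the same place would help to separate the two. Also open, from the compounds shown here alone, is how this position would respond to a group of another kind, such as an amine or a carboxylic acid on the ring.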